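Removing a Methoxy Group from an Inactive Compound

This account rests on a few compounds, and the source may have more. Where it says the series, first, only, none or still open, it means among the compounds named here.

Measured in a functional assay on COLO 205 cells (Homo sapiens) for cytotoxicity, read by MTT assay, with a stated time of 24 h; a lower number here means a stronger inhibitor of growth, a higher number a weaker inhibitor of growth:
compound 1 `COc1ccc(/C=C/C(=O)c2ccc(OCC=C(C)C)cc2O)cc1OC`: > 100000 nM
compound 2 `COc1ccc(/C=C/C(=O)c2ccc(OCC=C(C)C)cc2OCC=C(C)C)c(OC)c1OC`: > 100000 nM

Neither result is a true number. Compound 2 gives only a limit, > 100000 nM. Compound 1 also gives only a limit, > 100000 nM. On these data alone, the two compounds therefore share one reading, (the limit of > 100000 nM in this assay, at which 2 of the 2 values shown sit), and how far the real values lie past it is unknown.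

Compound 3 `COc1ccc(/C=C/C(=O)c2ccc(OCC=C(C)C)cc2OCC=C(C)C)cc1OC` has hydrogen in place of methoxy on an aromatic carbon, ortho to a large group (hydrogen in place of methoxy on an aromatic carbon). Within the data shown here, no measured pair shows what such a change does in this assay. So no step beyond the scatter is expected, and no direction can be favoured: the expected change is a number no higher from compound 2 to compound 3 (the limit leaves the size open). The estimate for compound 3 is 100000 nM, with an expected range of 30000 nM to 300000 nM, and another reading at the limit is quite likely.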

Compound 3, concentration for 50% growth inhibition: 90000 nM
The estimate for compound 3 lay 1.1-fold (0.05 log units) above the measured number; the measured number falls inside the stated range.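

In this assay compound 3 gives 90000 nM, a true number and not a limit, the only one among the compounds shown. Hydrogen in place of methoxy on this aromatic carbon gives an at least 1.1-fold lower number from compound 2 to compound 3 (0.04 log units; that floor lies within the scatter), and 3-methylbut-2-en-1-yl in place of hydrogen on an oxygen on an aromatic ring gives an at least 1.1-fold lower number from compound 1 to compound 3 (0.04 log units; that floor lies within the scatter). Neither step has a known size, because the real values of the two other compounds lie somewhere past one shared reading: the limit of > 100000 nM in this assay, at which 2 of the 3 values shown sit.

On these data alone, whether another group on this aromatic carbon, such as an amine or a fluorine atom, would shift the number further remains open. So does whether a shorter chain, such as methyl, on that oxygen would give a true reading with the methoxy group kept in place.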